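A few compounds are considered here, and "the series" means these few. Any claim that something is new, unique, unknown or untested is made for them only; others in the source may bear on it.

Compound 1 `O=C(Nc1ccc([N+](=O)[O-])cc1)c1cc(Cl)ccc1O` is the one of the three measured compounds that gives a number in a physicochemical assay for solubility; on this read-out lower numbers stand for lower solubility and higher numbers for higher solubility: compound 1 gives 6.4 ug/mL. Compound 2 `O=C(Nc1ccc([N+](=O)[O-])c(Cl)c1)c1cc(Cl)ccc1O` differs from compound 1 by chloro in place of hydrogen on an aromatic carbon. In this assay compound 2 gives only a limit of the assay, < 1 ug/mL. The step is an at least 6.4-fold lower number from compound 1 to compound 2 (0.80 log units; beyond the scatter). Compound 3 `O=C(Nc1ccc(C(F)(F)F)cc1)c1cc(Cl)ccc1O` differs from compound 1 by trifluoromethyl in place of nitro on an aromatic carbon. In this assay compound 3 likewise gives only a limit, < 1 ug/mL. Compound 4 `O=C(Nc1ccc(C(F)(F)F)cc1Cl)c1cc(Cl)ccc1O` is not yet measured; it differs from compound 3 by chloro in place of hydrogen on an aromatic carbon, the same kind of change as from compound 1 to compound 2, though here the chloro sits ortho to a large group and meta to a trifluoromethyl group rather than ortho to a nitro group and meta to a large group. The expected step that the limit leaves unreadable from compound 3 to compound 4 is set beside an at least 6.4-fold lower number from compound 1 to compound 2 (0.80 log units; beyond the scatter), resting on that earlier step and on compound 3 already sitting at the limit of < 1 ug/mL in this assay, at which 2 of the 3 values shown sit. Compound 4 is therefore estimated at 0.3 ug/mL, between 0.05 ug/mL and 1.2 ug/mL.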

Compound 4, solubility: < 1 ug/mL
Compound 4 ended at the assay's limit (the forecaster's own chance of this, stated with the estimate: 85%); the middle value does not contradict the limit.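

In this assay the step from compound 3 to compound 4 cannot be read, as both compounds give only the same limit: the limit of < 1 ug/mL in this assay, at which 3 of the 4 values shown sit.

The compounds shown leave open whether chloro in place of hydrogen changes this read-out at all in compound 4.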